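The source may hold more compounds than are shown below. What is called first, only, known or untested is meant among the compounds shown, and "the series" means these compounds.

Compound 1 `c1ccc([C@H]2COC3(CCCN[C@H]3c3ccccc3)C2)cc1` gives 133 nM in an assay on CHO cells for displacement of a labelled ligand from Substance-P receptor (Homo sapiens); a higher number here means a weaker inhibitor, a lower number a stronger inhibitor.
Compound 2 `COc1ccc(-n2nnnc2C(F)(F)F)cc1[C@H]1COC2(CCCNC2c2ccccc2)C1` gives 0.11 nM in this assay.
Compound 3 `COc1ccc(-n2nnnc2C(F)(F)F)cc1[C@H]1COC2(CCCN(Cc3n[nH]c(O)n3)C2c2ccccc2)C1` gives 0.1 nM in this assay.

In this assay compound 3 gives the lowest of the three numbers, though compound 2 differs from it only within the scatter, whereas compound 1 lies far higher. Compound 4 `COc1ccc(-n2nnnc2C(F)(F)F)cc1[C@H]1COC2(CCCN(Cc3c[nH]cn3)C2c2ccccc2)C1` differs from compound 3 in one place: 1H-imidazol-4-yl in place of 5-hydroxy-1H-1,2,4-triazol-3-yl on a saturated chain carbon bound to an amine nitrogen in a ring. Going by the values given here, only one measured step touches this place on the shared core, a 1.1-fold lower number from compound 2 to compound 3 (0.04 log units; within the scatter), where attaching the whole group to the ring amine, which carried a hydrogen in compound 2, left the number unchanged within the scatter. Among the compounds with values here, no measured pair compares two different groups on that ring amine, so the swap of one five-membered ring for another can only be judged by analogy with that single step. Since adding the larger group made no difference, a smaller related ring in the same position is expected to behave alike, and the expected step is a 1.2-fold higher number from compound 3 to compound 4 (0.08 log units; within the scatter). Compound 4 is therefore estimated at 0.12 nM, with a range of 0.04 nM to 0.4 nM.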

Compound 4, half-maximal inhibitory concentration: 0.11 nM
Compound 4: the middle estimate sits 1.1-fold (0.04 log units) above what was measured, and the stated range covers the measured number.
By their numbers in this assay, from the lowest: compounds 3, 2 and 4 (each within the scatter of the next); then compound 1.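

In this assay, going by these compounds alone, the new result gives the first direct comparison of two different groups on the ring amine: 1H-imidazol-4-yl in place of 5-hydroxy-1H-1,2,4-triazol-3-yl gives a 1.1-fold higher number from compound 3 to compound 4 (0.04 log units; within the scatter). The comparison with the unsubstituted ring amine gives no change at the digits printed from compound 2 to compound 4 (within the scatter), so both five-membered aromatic rings, which differ in their hetero atoms and in their hydrogen-bond donors and acceptors, now stand within the scatter of hydrogen at this place. No supporting information is available to explain why these changes leave the number so little altered.

Within the data shown here, these are only two groups of one kind, both five-membered aromatic rings on a single saturated chain carbon. On these data alone, how a carboxylic acid or a simple amine at the end of that chain would read stays open, as does the effect of a longer chain between the ring amine and the ring.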